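The compounds below may be only part of what the source reports. "The series", "measured", "known", "first", "only" and "open" are said of these compounds alone.

Compound 1 `NC1CCC(Nc2nc(NCc3ccc(-c4cccc(F)c4)cc3)c3ncn(C4CCCC4)c3n2)CC1` and compound 2 `NC1CCC(Nc2nc(NCc3ccc(-c4ccco4)cc3)c3ncn(C4CCCC4)c3n2)CC1` share one core and differ by furan-2-yl in place of 3-fluorophenyl on an aromatic carbon. In a functional assay on K562 cells (Homo sapiens) for inhibition, with a stated time of 72 h (on this read-out higher numbers stand for weaker inhibition and lower numbers for stronger inhibition), compound 1 gives 290 nM, while compound 2 gives 96 nM, so the change brought a 3.0-fold lower number from compound 1 to compound 2 (0.48 log units; beyond the scatter). Compound 3 `NC1CCC(Nc2nc(NCc3ccc(-c4cccc(F)c4)nc3)c3ncn(C4CCCC4)c3n2)CC1` carries a different core; how the two cores differ is not broken down here. In this assay compound 3 gives 61 nM. Compound 4 `NC1CCC(Nc2nc(NCc3ccc(-c4ccco4)nc3)c3ncn(C4CCCC4)c3n2)CC1` differs from compound 3 by furan-2-yl in place of 3-fluorophenyl on an aromatic carbon. This is the same kind of change as before, but not the same: it now sits on a ring with one nitrogen, next to the ring nitrogen, rather than on a ring of carbon only. A step of similar size, a 2.4-fold lower number from compound 3 to compound 4 (0.39 log units; beyond the scatter), is expected because of a 3.0-fold lower number from compound 1 to compound 2 (0.48 log units; beyond the scatter). Compound 4 is therefore estimated at 25 nM, with a range from 10 nM to 70 nM.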

Compound 4, half-maximal inhibitory concentration: 67 nM
Compound 4: the middle estimate sits 2.7-fold (0.43 log units) below what was measured, and the stated range covers the measured number.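

In this assay the change from 3-fluorophenyl to furan-2-yl did not carry over with the same size from one core to the other: the same change on two cores in this assay, a 3.0-fold lower number (0.48 log units; beyond the scatter) from compound 1 to compound 2 and a 1.1-fold higher number (0.04 log units; within the scatter) from compound 3 to compound 4, 3.3-fold (0.52 log units) apart, beyond the scatter of two such steps

On the second core the same change brought a 1.1-fold higher number from compound 3 to compound 4 (0.04 log units; within the scatter), and with furan-2-yl held in place the change of core brought a 1.4-fold lower number from compound 2 to compound 4 (0.16 log units; within the scatter), so neither step separates these compounds from one another. Within the data shown here, with only one pair on each core, this shows that the step depends on the core here, but it does not show why, or whether this holds for other groups.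

Going by these compounds, it remains open whether a plain phenyl, a thiophen-2-yl or an aminomethyl group at this place would show the same difference between the two cores. On these data alone, it also remains open whether the pattern extends beyond this cell assay.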